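This account rests on a few compounds, and the source may have more. Where it says the series, first, only, none or still open, it means among the compounds named here.

In a functional assay on SK-MEL-28 cells (Homo sapiens) for inhibition (a higher number here means a weaker inhibitor, a lower number a stronger inhibitor), compound 1 `COCCOc1cc(/C=C/c2ccc3ccccc3c2)ccc1OC` gives 2990 nM. Compound 2 `COCCOc1cc(/C=C\c2ccc3ccccc3c2)ccc1OC` gives 2990 nM, level with compound 1. Compound 3 `FC(F)(F)Oc1ccc(/C=C/c2ccc3ccccc3c2)cc1` is recorded only as a limit, > 5000 nM. The next structure is compound 4 `COc1ccc(/C=C\c2ccc3ccccc3c2)cc1[N+](=O)[O-]`, with this change from compound 2: nitro in place of 2-methoxyethoxy on an aromatic carbon. Among the measured compounds shown here, the one measured step, no change at the digits printed from compound 1 to compound 2 (within the scatter), rests on (the fact that compounds 1 and 2 differ only in the configuration as drawn), so it gives no size for an exchange of substituents. For the measured compounds named here, with no measured step of this kind, no shift beyond the scatter is expected, and the uncertainty is wide in both directions. The estimate is a 1.5-fold lower number from compound 2 to compound 4 (0.17 log units; within the scatter). For compound 4 the expected value is 2000 nM, with an estimated range of 300 nM to 5000 nM.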

Compound 4, half-maximal inhibitory concentration: > 20000 nM
Compound 4 was reported as a limit (the forecaster's own chance of this, stated with the estimate: 25%); middle value at least 10-fold (1.00 log units) from the limit.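

In this assay, nitro in place of 2-methoxyethoxy on this aromatic carbon, ortho to a methoxy group, gives an at least 6.6-fold higher number from compound 2 to compound 4 (0.82 log units; beyond the scatter). Compound 4 stands only as a limit, > 20000 nM, so the full size of the step stays unread. Unlike the earlier step, which concerned configuration only, this is an exchange of substituents, and it shows that this position responds to the group it carries, at least for this pair.

From the compounds shown here alone, whether the shift follows from losing 2-methoxyethoxy or from gaining nitro remains open. Going by these compounds, how an amine or a plain ethoxy group would read at this position also remains open.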